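The source may report more compounds than this note shows. Statements on the series, on what has been measured and on what is new or still open speak of the compounds shown alone.

Compound 1 `COc1ncnc2c1c(-c1cccs1)cn2[C@@H]1O[C@H](CO)[C@@H](O)[C@H]1O` carries on the shared core a methoxy group and a thiophen-2-yl group. Among the compounds with values here, in a functional assay on CEM-DNR-bulk cells (Homo sapiens), read by MTT assay, with a stated time of 72 h (a lower number here means a stronger inhibitor, a higher number a weaker inhibitor), compound 1 gives 12100 nM, the only full number in this set. Compound 2 `Cc1ncnc2c1c(-c1cccs1)cn2[C@@H]1O[C@H](CO)[C@@H](O)[C@H]1O` has methyl in place of methoxy on an aromatic carbon. In this assay compound 2 reaches only the limit > 20000 nM. That step, an at least 1.6-fold higher number from compound 1 to compound 2 (0.21 log units; that floor lies within the scatter), touches the methoxy group and not the thiophene, and it sits at the limit of > 20000 nM in this assay, at which 1 of the 2 values shown sits. Compound 3 `COc1ncnc2c1c(-c1ccco1)cn2[C@@H]1O[C@H](CO)[C@@H](O)[C@H]1O` differs from compound 1 elsewhere: furan-2-yl in place of thiophen-2-yl on an aromatic carbon. Within the data shown here, no measured step covers this exchange, so the data give no direction for it. For compound 3 a step of a 1.2-fold higher number from compound 1 to compound 3 (0.09 log units; within the scatter) is expected, no larger than the scatter. Compound 3 is therefore estimated at 15000 nM, within a range from 6000 nM to 40000 nM.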

Compound 3, half-maximal inhibitory concentration: 160 nM
For compound 3 the middle estimate is 94-fold (1.97 log units) above the measured one; the whole stated range lies above it.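

The two groups at this position look closely alike: thiophen-2-yl and furan-2-yl have the same count of heavy atoms, and each is one five-membered aromatic ring with 1 hetero atom, differing only in sulfur against oxygen. Even so, in this assay this exchange gives a 76-fold lower number from compound 1 to compound 3 (1.88 log units; beyond the scatter), the only step in this set that is printed as clearly beyond the scatter, so this position responds strongly to a change of a single ring atom. The data shown give no reason for the size of this step.

Still open, going by these compounds, is whether methyl in place of methoxy on the shared core would have a similar outcome when furan-2-yl is present. On these data alone, it is also open how a phenyl ring, an amine or a longer alkyl chain would fare on this aromatic carbon.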